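Cytotoxicity notes: varying the amide-type nitrogen group

The source may hold more compounds than are shown below. What is called first, only, known or untested is meant among the compounds shown, and "the series" means these compounds.

Three compounds share one core and differ only in the group on the amide-type nitrogen. Compound 1 `COC(=O)c1sccc1NC(=O)CSc1nncnc1-c1ccccc1Cl` gives 105000 nM in an ADME assay on MT4 cells (Homo sapiens) for cytotoxicity, read by MTT assay; on this read-out higher numbers stand for lower toxicity in this test and lower numbers for higher toxicity in this test. Compound 2 `O=C(CSc1nncnc1-c1ccccc1Cl)Nc1ccc(Cl)cc1Cl` gives 51000 nM in this assay; the step of a 2.1-fold lower number from compound 1 to compound 2 (0.31 log units; beyond the scatter) is the only one beyond the scatter. Compound 3 `O=C(CSc1nncnc1-c1ccccc1Cl)Nc1ccccc1[N+](=O)[O-]` gives 63000 nM in this assay; the step of a 1.7-fold lower number from compound 1 to compound 3 (0.22 log units; within the scatter) and the step of a 1.2-fold higher number from compound 2 to compound 3 (0.09 log units; within the scatter) both stay within the scatter. Compound 3 thus stands second highest of the three numbers, with compound 2 nearest and compound 1 furthest, neither separated from it beyond the scatter.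

Compound 4 `O=C(CSc1nncnc1-c1ccccc1Cl)Nc1ccccc1Br` is not yet measured. Its difference from compound 3 is bromo in place of nitro on an aromatic carbon; cut one bond further out, this reads 2-nitrophenyl to 2-bromophenyl. For the measured compounds named here, no measured step exchanges one group for another at this place; the closest is a 1.2-fold higher number from compound 2 to compound 3 (0.09 log units; within the scatter), which replaces 2,4-dichlorophenyl with 2-nitrophenyl and stays within the scatter. Going by the values given here, all three values sit close together, and only the step of a 2.1-fold lower number from compound 1 to compound 2 (0.31 log units; beyond the scatter) exceeds the scatter. For compound 4 in this assay the expected step is therefore a 1.1-fold lower number from compound 3 to compound 4 (0.06 log units; within the scatter), none beyond the scatter. The estimate for compound 4 is 55000 nM, with a range from 25000 nM to 120000 nM.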

Compound 4, half-maximal cytotoxic concentration: 73000 nM
Compound 4: middle estimate off by 1.3-fold (0.12 log units), on the low side, and the stated range covers the measured number.
By their numbers in this assay, from the lowest: compounds 2, 3, 4 and 1 (each within the scatter of the next, the first and the last beyond it).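

In this assay, for the compounds shown here, the exchange at this place, on an aromatic carbon ortho to a large group, gives the first step that swaps one group directly for another here: a 1.2-fold higher number from compound 3 to compound 4 (0.06 log units; within the scatter). Nitro, with 3 heavy atoms and 2 hydrogen-bond acceptors, can thus give way to bromo, with 1 heavy atom and 0 hydrogen-bond acceptors, without the number leaving the scatter. Compound 4 also stays close to the two other compounds, with a 1.4-fold higher number from compound 2 to compound 4 (0.16 log units; within the scatter) and a 1.4-fold lower number from compound 1 to compound 4 (0.16 log units; within the scatter), so it is not separated from any of the three, even though compound 1 and compound 2 lie apart beyond the scatter; nothing on hand gives a reason for this flat result.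

On these data alone, whether an amine or a carboxylic acid in place of bromo would carry the number beyond the scatter remains open. Also open, as far as these compounds go, is what a longer chain on the amide-type nitrogen would do to the number in this assay.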